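From isopropyl to cyanomethyl: a clearance estimate for compound 4

The compounds below may be only part of what the source reports. "The series", "measured", "known", "first", "only" and "open" are said of these compounds alone.

In an in vitro ADME assay on microsomes from liver (Mus musculus) for pharmacokinetics, read by LC-MS, with a stated time of 10 min, tested at 1 uM (a higher number here means faster removal of the compound, a lower number slower removal), compound 1 `COc1ccc(NC(=O)[C@H]2CN(C)C[C@@H]2c2ccc(/C=C/C(=O)Nc3ccccc3N)cc2)cc1` gives 54 mL/min/kg, and compound 2 `CN1C[C@H](C(=O)Nc2ccc(F)c(F)c2)[C@@H](c2ccc(/C=C/C(=O)Nc3ccccc3N)cc2)C1` gives 46 mL/min/kg. Compound 3 `CC(C)N1C[C@H](C(=O)Nc2ccc(Cl)cc2)[C@@H](c2ccc(/C=C/C(=O)Nc3ccccc3N)cc2)C1` gives 38 mL/min/kg, which lies within the usual scatter of both other values.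

The next structure, compound 4 `N#CCN1C[C@H](C(=O)Nc2ccc(Cl)cc2)[C@@H](c2ccc(/C=C/C(=O)Nc3ccccc3N)cc2)C1`, carries cyanomethyl in place of isopropyl on an amine nitrogen in a ring. The rest of the molecule stays the same as in compound 3.

For the measured compounds named here, only one measured step changes a single place, a 1.2-fold lower number from compound 1 to compound 2 (0.07 log units; within the scatter). It puts 3,4-difluorophenyl in place of 4-methoxyphenyl on an amide-type nitrogen, and it stays within the scatter. Going by the values given here, that is a different site, and no measured step isolates a change on the amine nitrogen in a ring. The data therefore point in neither direction, and no shift beyond the scatter is expected in this assay.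

The expected result is a 1.1-fold higher number from compound 3 to compound 4 (0.02 log units; within the scatter), which is within the scatter. For compound 4 the estimated clearance is 40 mL/min/kg, with an expected range of 22 mL/min/kg to 70 mL/min/kg.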

Compound 4, clearance: 51 mL/min/kg
For compound 4 the middle estimate is 1.3-fold (0.11 log units) below the measured one; the measured number falls inside the stated range.
By their numbers in this assay, from the lowest: compounds 3, 2, 4 and 1 (each within the scatter of the next).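

In this assay, the amine nitrogen in the ring now has a measured step of its own: cyanomethyl in place of isopropyl gives a 1.3-fold higher number from compound 3 to compound 4 (0.13 log units; within the scatter) and so stays inside the usual scatter. For the compounds shown here, the earlier single-place step concerned only the amide-type nitrogen, so this is the first sign that a change at this ring nitrogen can bring in a nitrile without a clear shift in clearance. No supporting measurement bears on this result.

This reading rests on one pair with the 4-chlorophenyl amide, and compounds 1 and 2 differ from it in more than one place, so they cannot extend it. Going by these compounds, how an acetyl group, a 2-hydroxyethyl group or a longer alkyl chain on this nitrogen would read remains open.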